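Aryl sulfone acetic acids: distribution at neutral pH

The source may hold more compounds than are shown below. What is called first, only, known or untested is meant among the compounds shown, and "the series" means these compounds.

Measured compounds:
- compound 1, `O=C(O)CS(=O)(=O)c1ccc(OCc2cccc(-c3ccccc3C(F)(F)F)c2)cc1`: 2.95
- compound 2, `COc1ccccc1-c1cccc(COc2ccc(S(=O)(=O)CC(=O)O)cc2)c1`: "not determined" (no result reported)

In a physicochemical assay for lipophilicity, using the shake flask method, in phosphate buffer, measured as octanol-water partition, with a stated time of 24 h, at pH 7.4, tested at 100 uM (a lower number here means a more polar compound, a higher number a more lipophilic compound), compound 1 gives 2.95. Compound 2 has no single number in this assay, where it gives "not determined" (no result reported); its place on the scale is therefore open, and the only anchor in the series is compound 1. Among the measured compounds shown here, no two measured compounds differ in a single place, so no measured step exists from which a size could be read.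

The next compound is compound 3, `CCOc1ccc(-c2cccc(COc3ccc(S(=O)(=O)CC(=O)O)cc3)c2)c(Cl)c1`. Relative to compound 2 the change is 2-chloro-4-ethoxyphenyl in place of 2-methoxyphenyl on an aromatic carbon. The group that enters is the larger of the two, as counted above, and the rest of the molecule is unchanged.

Without a measured step, the expectation rests on the anchor value of compound 1 and on the counted change alone: a step upward in this assay of moderate size, beyond the usual scatter, is expected for compound 3 relative to where compound 2 would stand. For compound 3 in this assay a value of 3.3 is estimated, expected to lie between 2.7 and 3.9.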

Compound 3, distribution coefficient: 3.12
Compound 3: middle estimate off by 0.18 log units, on the high side; low and high end bracket the measured number.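

Among the compounds shown here, compound 3 supplies the first measured step: in this assay, 2-chloro-4-ethoxyphenyl in place of 2-(trifluoromethyl)phenyl on an aromatic carbon, meta to a large group, gives a number 0.17 log units higher from compound 1 to compound 3 (within the scatter), so on this scale the two substituted phenyl groups cannot be told apart, and the anchor of compound 1 now has a partner that shares the same core. The step from compound 2 to compound 3 cannot be read, since compound 2 has no single number, and the 2-methoxyphenyl group therefore has no place on this scale relative to the other two groups. No supporting measurement accompanies this result, so the step stands as an observation without an assigned cause.

The compounds shown hold only substituted phenyl groups at this position, and a single step within the scatter says nothing about how far the scale can move there. From the compounds shown here alone, what an amine or a longer alkyl chain on the same aromatic carbon would give in this assay remains open, as does the effect of any change elsewhere on the shared core.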